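Antiproliferative series: removing a ring hydroxy from compound 2

The compounds below may be only part of what the source reports. "The series", "measured", "known", "first", "only" and "open" are said of these compounds alone.

Measured compounds:
compound 1 `COC(=O)[C@]1(Cc2ccc(O)c(CC=C(C)C)c2)OC(=O)C(O)=C1c1ccccc1`: > 20000 nM
compound 2 `COC(=O)[C@]1(Cc2ccc3c(c2)C[C@H](O)C(C)(C)O3)OC(=O)C(O)=C1c1ccc(O)cc1`: > 20000 nM

Both compounds were tested in a functional assay on BEAS-2B cells (Homo sapiens) for antiproliferative activity, read by CCK-8 assay, with a stated time of 24 h; a higher number here means a weaker inhibitor, a lower number a stronger inhibitor. For compound 1 the reported value is a limit of the assay, > 20000 nM. For compound 2 the reported value is likewise a limit of the assay, > 20000 nM. Thus compound 2 stands at the limit together with the other value shown: the limit of > 20000 nM in this assay, at which 2 of the 2 values shown sit. Among the measured compounds shown here, no step between the two measured compounds can be stated, since neither carries a number, and they differ in more than one place.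

The next compound is compound 3 `COC(=O)[C@]1(Cc2ccc3c(c2)CCC(C)(C)O3)OC(=O)C(O)=C1c1ccc(O)cc1`. It differs from compound 2 by hydrogen in place of hydroxy on a saturated ring carbon. For the measured compounds named here, with only limits in hand there is no measured step to build on. The step that the limit leaves unreadable from compound 2 to compound 3 is expected to be none beyond the scatter, with a limit the most likely outcome. Compound 3 is therefore expected to come out near 25000 nM in this assay, within a range from 8000 nM to 80000 nM.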

Compound 3, half-maximal inhibitory concentration: > 20000 nM
Compound 3 ended at the assay's limit; the forecaster's own chance of this, stated with the estimate: 80%; the middle value does not contradict the limit.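

In this assay compound 3 gives > 20000 nM, which is a limit of the assay. Compound 2 also stands at a limit, so no step from compound 2 to compound 3 can be read: the limit of > 20000 nM in this assay, at which 3 of the 3 values shown sit.

The compounds shown leave open whether exchanging hydroxy for hydrogen on the saturated ring carbon changes the result in this assay at all.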